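Compound 1 to compound 3: replacing aminomethyl with carbamoyl

A few compounds are considered here, and "the series" means these few. Any claim that something is new, unique, unknown or untested is made for them only; others in the source may bear on it.

Measured so far in an ADME assay on L6 cells (Rattus norvegicus) for cytotoxicity, read by resazurin assay, with a stated time of 72 h; a lower number here means a stronger inhibitor, a higher number a weaker inhibitor:

compound 1 (`NCCN1CCC2(N3CCCC3)CC(c3ccc(Cl)cc3)C1C(c1ccc(Cl)cc1)C2`) gives 4650 nM
compound 2 (`O=C(O)CN1CCC2(N3CCCCC3)CC(c3ccc(Cl)cc3)C1C(c1ccc(Cl)cc1)C2`) gives "not determined" (no result reported)

Among the measured compounds shown here, compound 1 holds the only number here, so it cannot yet be ranked against anything, and compound 2 offers no comparison. The next compound to be tested is compound 3 (`NC(=O)CN1CCC2(N3CCCC3)CC(c3ccc(Cl)cc3)C1C(c1ccc(Cl)cc1)C2`), which keeps the core of compound 1 but has carbamoyl in place of aminomethyl on a saturated chain carbon bound to an amine nitrogen in a ring. For the measured compounds named here, no measured step between similar compounds is available as a guide, so the expectation rests on the structural change and on compound 1 at 4650 nM alone. A moderate move towards weaker inhibition, meaning a higher number, is expected, with an estimated size of a 3.9-fold higher number from compound 1 to compound 3 (0.59 log units; beyond the scatter) in this assay as the read-out. Compound 3 is estimated at 18000 nM (expected range 6000 nM to 60000 nM).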

Compound 3, half-maximal inhibitory concentration: 23900 nM
Compound 3: the middle estimate sits 1.3-fold (0.12 log units) below what was measured; the range from low to high includes it.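

Among the compounds shown here, this is the first comparison at this position. With the shared core unchanged, carbamoyl in place of aminomethyl on a saturated chain carbon bound to an amine nitrogen in a ring gives a 5.1-fold higher number from compound 1 to compound 3 (0.71 log units; beyond the scatter) in this assay, a modest step but one beyond the usual scatter, so this reading responds to what the chain carries. The data offer no explanation for the shift.

Going by these compounds, with a single step, it stays open whether this is a trend or a feature of these two groups alone, and compound 2 has no number, so any step involving it cannot be read. Also open, on these data alone, is where a longer chain ending in an amine, or a hydroxyl or sulfonamide in place of carbamoyl, would fall on this scale.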